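The source may report more compounds than this note shows. Statements on the series, on what has been measured and on what is new or still open speak of the compounds shown alone.

Measured in a functional assay on HepG2 cells (Homo sapiens) for antiproliferative activity, read by MTT assay, with a stated time of 48 h; a lower number here means a stronger inhibitor of growth, a higher number a weaker inhibitor of growth:
- compound 1 `CCOC(=O)N1N=C(c2ccc(OC)cc2)CC1c1cc(OC)c(OC)c(OC)c1`: 9400 nM
- compound 2 `CCCOC(=O)N1N=C(c2ccc(OC)cc2)CC1c1cc(OC)c(OC)c(OC)c1`: > 10000 nM

Compound 2 gives only a limit and not a number: it stands at the limit of > 10000 nM in this assay, at which 1 of the 2 values shown sits.

Compound 3 `COc1ccc(C2=NN(C(=O)OCc3ccccc3)C(c3cc(OC)c(OC)c(OC)c3)C2)cc1` differs from it by phenyl in place of ethyl on a saturated chain carbon bound to an oxygen next to a carbonyl group. Phenyl takes the place of ethyl on a saturated chain carbon bound to an oxygen next to a carbonyl group, so propoxycarbonyl becomes benzyloxycarbonyl.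

Going by the values given here, one measured step bears on this chain: an at least 1.0-fold higher number from compound 1 to compound 2 (0.02 log units; that floor lies within the scatter). That step adds only a methyl in place of hydrogen, and its floor lies within the scatter. Among the compounds with values here, no measured compound carries a ring at this place, so the evidence is thin and the range must stay wide.

The expected change, an at least 1.1-fold lower number from compound 2 to compound 3 (0.04 log units; that floor lies within the scatter), is no step beyond the scatter in either direction. Compound 3 is estimated at 9000 nM, with an expected range from 3000 nM to 20000 nM.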

Compound 3, concentration for 50% growth inhibition: > 10000 nM
Compound 3: no number, only a limit; the forecaster's own chance of this, stated with the estimate: 45%; at least 1.1-fold (0.04 log units) between middle value and limit.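

In this assay compound 3 gives > 10000 nM, which is a limit of the assay and not a number. A six-membered aromatic ring of carbon only now stands on the saturated chain carbon bound to an oxygen next to a carbonyl group, and this larger group also gives no number: the limit of > 10000 nM in this assay, at which 2 of the 3 values shown sit. Phenyl in place of methyl gives an at least 1.0-fold higher number from compound 1 to compound 3 (0.02 log units; that floor lies within the scatter), so no change at this place can yet be told from the scatter, and the step between the two limits cannot be read.

On these data alone, how far compound 2 and compound 3 lie beyond their limits stays open. So does what a methoxycarbonyl group, or a benzyloxycarbonyl group with an amine or a carboxylic acid on its phenyl ring, would give at this place.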